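Methylamino in place of azido on the shared core

A few compounds are considered here, and "the series" means these few. Any claim that something is new, unique, unknown or untested is made for them only; others in the source may bear on it.

Compound 1, `OC[C@H]1OC(n2cnc3c(NCc4ccccc4)nccc32)[C@H](O)[C@@H]1O`, in a functional assay on EL4 cells (Mus musculus) for inhibition, tested at 100 uM (on this read-out lower numbers stand for less inhibition and higher numbers for more inhibition at the one concentration tested (going by the name of the read-out)), gives 5%.
Compound 2, `OC[C@H]1OC(n2cnc3c(Cl)nccc32)[C@H](O)[C@@H]1O`, in this assay gives < 5%, which is a limit of the assay.
Compound 3, `[N-]=[N+]=Nc1nccc2c1ncn2C1O[C@H](CO)[C@@H](O)[C@H]1O`, in this assay gives < 5%, again a limit of the assay.

Compound 3 thus stands at the limit of < 5% in this assay, at which 2 of the 3 values shown sit, and no number is known for it. Compound 4, `CNc1nccc2c1ncn2C1O[C@H](CO)[C@@H](O)[C@H]1O`, has not been measured; it differs from compound 3 in that (methylamino in place of azido on an aromatic carbon). The steps that touch compound 3 are a number no higher from compound 1 to compound 3 (the limit leaves the size open) and a step that the two limits leave unreadable from compound 2 to compound 3, and the step of a number no higher from compound 1 to compound 2 (the limit leaves the size open) is likewise unreadable in size, so none of them tells how large a change on this carbon can be. Compound 1 carries an amino group on the same carbon and gives only 5%, so compound 4 is expected to give little inhibition as well, about 5% in this assay, between 0% and 15%. The step that this estimate means, a number no lower from compound 3 to compound 4 (the limit leaves the size open), is expected to lie within the scatter.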

Compound 4, a percentage reported as inhibition, at one concentration (the size of the read-out at that concentration, not a potency): 11%
For compound 4 the middle estimate is 6 percentage points below the measured one, and the stated range covers the measured number.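

In this assay, methylamino in place of azido gives a number at least 6 percentage points higher from compound 3 to compound 4 (that floor lies within the scatter) and methylamino in place of chloro gives a number at least 6 percentage points higher from compound 2 to compound 4 (that floor lies within the scatter) on this aromatic carbon, so neither change is shown to go beyond the scatter. Trimming the side chain, with hydrogen in place of phenyl, gives a number 6 percentage points higher from compound 1 to compound 4 (within the scatter) and shows that the read-out does not separate methylamino from benzylamino on the shared core. Compound 2 and compound 3 each remain a limit and not a number, so the steps that start from them are floors only: the limit of < 5% in this assay, at which 2 of the 4 values shown sit.

Going by these compounds, whether a free amine, a dimethylamino group or a longer alkylamino chain on this carbon would move the read-out beyond the scatter stays open. Also open, on these data alone, is whether a hydroxyl or a methoxy group here would behave like methylamino or like chloro.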